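Replacing Bromine with Methylsulfanylphenyl on Compound 3

The compounds below may be only part of what the source reports. "The series", "measured", "known", "first", "only" and "open" are said of these compounds alone.

For the measured compounds named here, compound 3 `O=C(CCc1cccc2c1B(O)OC2)Nc1cccc(Br)c1` carries the only measured number in this set: in a functional assay on HCT-116 cells (Homo sapiens) for antiproliferative activity, read by MTT assay, with a stated time of 72 h (a higher number here means a weaker inhibitor, a lower number a stronger inhibitor), compound 3 gives 1400 nM. Compound 1 `CC(C)(C)NC(=O)CCc1cccc2c1B(O)OC2` reaches only a limit of this assay, at > 100000 nM. Compound 2 `O=C(CCc1cccc2c1B(O)OC2)Nc1nccs1` likewise stops at a limit, at > 100000 nM. Both sit at the limit of > 100000 nM in this assay, at which 2 of the 3 values shown sit. The steps of an at least 71-fold lower number from compound 1 to compound 3 (1.85 log units; beyond the scatter) and an at least 71-fold lower number from compound 2 to compound 3 (1.85 log units; beyond the scatter) show that 3-bromophenyl on the amide-type nitrogen brings the first readable number, while a step that the two limits leave unreadable from compound 1 to compound 2 cannot be read. Compound 4 `CSc1cccc(-c2cccc(NC(=O)CCc3cccc4c3B(O)OC4)c2)c1` differs from compound 3 by 3-(methylsulfanyl)phenyl in place of bromo on an aromatic carbon. Going by the values given here, no measured step alters a group on the 3-bromophenyl ring, so none bears directly on this change. The step of a 1.4-fold lower number from compound 3 to compound 4 (0.15 log units; within the scatter) is therefore expected to stay within the scatter. Compound 4 is estimated at 1000 nM, ranging from 200 nM to 6000 nM.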

Compound 4, half-maximal inhibitory concentration: 110 nM
Compound 4: the middle estimate sits 9.1-fold (0.96 log units) above what was measured; measured number below the stated range.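

For the compounds shown here, the earlier compounds varied only the group on the amide-type nitrogen, whereas this change is the first to alter the aromatic carbon that held bromo, and it gives a 13-fold lower number from compound 3 to compound 4 (1.10 log units; beyond the scatter) in this assay. The number therefore also responds to what stands at this place, and a 3-(methylsulfanyl)phenyl group is accepted there. Nothing measured here gives a cause for this gain. As far as these compounds go, it remains open whether the added ring alone or its methylsulfanyl group accounts for the step. A plain phenyl, or a phenyl carrying a methoxy group or an amine, would separate these, but none is among the compounds shown.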